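A few compounds are considered here, and "the series" means these few. Any claim that something is new, unique, unknown or untested is made for them only; others in the source may bear on it.

Within the data shown here, in a functional assay on UACC-62 cells (Homo sapiens) for cytotoxicity, read by sulforhodamine B assay, with a stated time of 24 h (a lower number here means a stronger inhibitor of growth, a higher number a weaker inhibitor of growth), compound 2 `O=C(/C=C/c1cc2ccccc2[nH]c1=O)c1ccc(O)cc1` gives 8730 nM, the lowest of the two numbers so far; compound 1 `COc1ccc(C(=O)/C=C/c2cc3ccccc3[nH]c2=O)cc1` gives 19300 nM, and the only measured step, a 2.2-fold lower number from compound 1 to compound 2 (0.34 log units; beyond the scatter), concerns a hydrogen replacing a methyl on a ring oxygen. Compound 3 `O=C(/C=C/c1cc2ccccc2[nH]c1=O)c1ccc(Cl)cc1` differs from compound 2 by chloro in place of hydroxy on an aromatic carbon, a change of a different kind, so that single step bears on it only loosely. Without a closer precedent, compound 3 is expected to move by a 1.4-fold higher number from compound 2 to compound 3 (0.14 log units; within the scatter), and its value in this assay is estimated at 12000 nM, within 4000 nM to 40000 nM.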

Compound 3, concentration for total growth inhibition: 54300 nM
Compound 3: middle estimate off by 4.5-fold (0.66 log units), on the low side; the whole stated range lies below it.
By their numbers in this assay, from the lowest: compound 2; then compound 1; then compound 3.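

Replacing the oxygen substituent with chloro on this aromatic carbon, para to a large group, costs more than the change at the ring oxygen had: the piece records a 6.2-fold higher number from compound 2 to compound 3 (0.79 log units; beyond the scatter) and a 2.8-fold higher number from compound 1 to compound 3 (0.45 log units; beyond the scatter) in this series. Compound 3 is thus the weakest of the three, and both oxygen-bearing groups, hydroxy and methoxy, give lower numbers than chloro. No measurement here accounts for this order. As far as these compounds go, whether an amine or a carboxylic acid at this position would match hydroxy or fall nearer chloro remains open.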